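The source may hold more compounds than are shown below. What is called first, only, known or untested is meant among the compounds shown, and "the series" means these compounds.

Measured so far:

Compound 1, `COc1cc(C(C)=O)ccc1OCCCN1CCC(C(c2ccc(F)c(F)c2)c2ccc(F)c(F)c2)CC1`: in a functional assay (aorta) with Oryctolagus cuniculus as the target (a higher number here means weaker binding, a lower number tighter binding), compound 1 gives 2.51 nM.
Compound 2, `COc1cc(C(C)=O)ccc1OCCCCN1CCC(C(c2ccc(F)cc2)c2ccc(F)cc2)CC1`: in this assay compound 2 gives 2.51 nM.
Compound 3, `COC(=O)c1ccc(OCCCN2CCC(C(c3ccc(F)cc3)c3ccc(F)cc3)CC2)c(OC)c1`: in this assay compound 3 gives 1.26 nM.

Compound 3 has the lowest number of the three, but its gap to compound 1 and its gap to compound 2 both fall within the usual scatter of repeated measurements, so the three compounds cannot be told apart on these figures. All three share the same core, a piperidine carrying two fluorinated phenyl groups, joined through a short chain to an oxygen on an aromatic ring.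

Compound 4, `Nc1ccc(OCCCN2CCC(C(c3ccc(F)cc3)c3ccc(F)cc3)CC2)cc1`, has not yet been measured. It differs from compound 3 in one place: 4-aminophenyl in place of 2-methoxy-4-(methoxycarbonyl)phenyl on an oxygen on a saturated carbon. Among the measured compounds shown here, no pair of measured compounds differs in just this way, so no measured step guides the expectation directly. The group that leaves has 0 hydrogen-bond donors and 3 hydrogen-bond acceptors; the group that enters, 4-aminophenyl, has 1 hydrogen-bond donor and 1 hydrogen-bond acceptor and is the smaller of the two.

A moderate weakening is expected from compound 3 to compound 4 in this assay, a rise in the number beyond the scatter, estimated as a 6.3-fold higher number from compound 3 to compound 4 (0.80 log units; beyond the scatter). Compound 4 is expected to give about 8 nM, most likely between 2 nM and 40 nM.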

Compound 4, dissociation constant: 31.6 nM
For compound 4 the middle estimate is 4.0-fold (0.60 log units) below the measured one; low and high end bracket the measured number.
By their numbers in this assay, from the lowest: compounds 3, 1 and 2 (each within the scatter of the next); then compound 4.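

Among the compounds shown here, until this result, no two measured compounds differed in just one place, and their numbers lay within the scatter of one another, so nothing showed whether the group on this oxygen mattered. In this assay, 4-aminophenyl in place of 2-methoxy-4-(methoxycarbonyl)phenyl on an oxygen on a saturated carbon gives a 25-fold higher number from compound 3 to compound 4 (1.40 log units; beyond the scatter), a large step that shows the number responds strongly to this change, with the chain and the rest of the molecule left as they were. Nothing measured here accounts for the size of this step, so it cannot be tied to any particular property of either group.

The change removes the methoxy and the methoxycarbonyl groups and brings in the amine all at once, so the compounds shown cannot say which of these parts carries the step. A phenyl bearing only the methoxy group, or one bearing a carboxylic acid in place of the methoxycarbonyl, would help pull these parts apart, and a longer chain on compound 4 would test whether the step holds beyond this chain length.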